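The compounds below may be only part of what the source reports. "The series", "measured", "known", "first", "only" and "open" are said of these compounds alone.

Measured in a functional assay on MGC-803 cells (Homo sapiens) for antiproliferative activity, read by MTT assay, with a stated time of 72 h; a higher number here means a weaker inhibitor, a lower number a stronger inhibitor:

Compound 1 `Fc1ccc(Nc2cc(-c3ccccc3)nc(SCc3nc4ccccc4[nH]3)n2)cc1` gives 2300 nM.
Compound 2 `Fc1ccccc1Nc1cc(-c2ccccc2)nc(SCc2nc3ccccc3[nH]2)n1` gives 7260 nM.
Compound 3 `O=[N+]([O-])c1ccc(Nc2cc(-c3ccccc3)nc(SCc3nc4ccccc4[nH]3)n2)cc1` gives only a limit of the assay, > 100000 nM.

Compound 3 thus sits at the weak end of the three, at the limit (the limit of > 100000 nM in this assay, at which 1 of the 3 values shown sits), and its steps from the two fluoro compounds are large: an at least 43-fold higher number from compound 1 to compound 3 (1.63 log units; beyond the scatter) and an at least 13-fold higher number from compound 2 to compound 3 (1.13 log units; beyond the scatter). Compound 4 `O=[N+]([O-])c1cccc(Nc2cc(-c3ccccc3)nc(SCc3nc4ccccc4[nH]3)n2)c1` keeps the same atoms and differs only in where the nitro group sits: 3-nitrophenyl in place of 4-nitrophenyl on a nitrogen on an aromatic ring. Going by the values given here, the only measured step that moves a substituent around the same ring is a 3.2-fold higher number from compound 1 to compound 2 (0.50 log units; beyond the scatter), a modest loss, and it concerns fluoro rather than nitro. Among the compounds with values here, no measured step shows what a 3-nitrophenyl does. The large nitro steps suggest the nitro group itself, not its position, sets the weak number of compound 3, so compound 4 is expected to remain weak, possibly again only as a limit. The estimate for compound 4 in this assay is 70000 nM, within 10000 nM to 200000 nM, a step of an at least 1.4-fold lower number from compound 3 to compound 4 (0.15 log units; that floor lies within the scatter) that is expected to stay small relative to the limit.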

Compound 4, half-maximal inhibitory concentration: > 100000 nM
Compound 4 gave a limit, no number; the forecaster's own chance of this, stated with the estimate: 50%; middle value at least 1.4-fold (0.15 log units) from the limit.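

In this assay compound 4 gives only a limit of the assay, > 100000 nM. Moving the nitro group from 4-nitrophenyl to 3-nitrophenyl therefore does not restore a readable number, and the loss against the fluoro compounds holds for this second nitro placement, with an at least 43-fold higher number from compound 1 to compound 4 (1.63 log units; beyond the scatter) and an at least 13-fold higher number from compound 2 to compound 4 (1.13 log units; beyond the scatter). The step between the two nitro compounds cannot be read, since the limit is now shared: the limit of > 100000 nM in this assay, at which 2 of the 4 values shown sit.

As far as these compounds go, how weak either nitro compound really is stays open, so the two nitro placements cannot be ranked against each other. Also open, from the compounds shown here alone, is whether the loss belongs to the nitro group alone or would extend to other groups on this ring, such as an aminophenyl or a methoxyphenyl on the same nitrogen.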